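The compounds below may be only part of what the source reports. "The series", "measured", "known", "first", "only" and "open" are said of these compounds alone.

Values in a functional assay on U2OS cells (Homo sapiens) for cytotoxicity, read by MTT assay, with a stated time of 48 h; a higher number here means a weaker inhibitor, a lower number a stronger inhibitor
- compound 1 `Fc1cccc(-c2nc(Nc3ccc(Cl)cc3)c3cc(F)ccc3n2)c1` gives 38400 nM 
- compound 2 `Oc1ccccc1Nc1nc(-c2cccc(F)c2)nc2ccc(F)cc12` gives 41400 nM 

Compound 2 lies within the scatter of compound 1, and the two numbers set no order between them. Compound 3 `Cc1cccc(Nc2nc(-c3cccc(F)c3)nc3ccc(F)cc23)c1` has 3-methylphenyl in place of 2-hydroxyphenyl on a nitrogen on an aromatic ring. Going by the values given here, the only measured step at this place (a 1.1-fold higher number from compound 1 to compound 2 (0.03 log units; within the scatter)) stayed within the scatter, so no step beyond the scatter is expected in this assay for this change. The expected step is small (a 1.2-fold lower number from compound 2 to compound 3 (0.07 log units; within the scatter)). The estimated value for compound 3 is 35000 nM (range 15000 nM to 80000 nM).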

Compound 3, half-maximal inhibitory concentration: > 50000 nM
Compound 3 was reported as a limit; the forecaster's own chance of this, stated with the estimate: 12%; middle value at least 1.4-fold (0.15 log units) away from the limit.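

In this assay compound 3 is reported only as a limit: the limit of > 50000 nM in this assay, at which 1 of the 3 values shown sits.

The steps of an at least 1.2-fold higher number from compound 2 to compound 3 (0.08 log units; that floor lies within the scatter) and an at least 1.3-fold higher number from compound 1 to compound 3 (0.11 log units; that floor lies within the scatter) have floors within the scatter, so they set no order among the three compounds. Still, 3-methylphenyl, which has no hydrogen-bond donor or acceptor, gives no lower number than 2-hydroxyphenyl on this nitrogen.

From the compounds shown here alone, whether any group at this place can bring the number clearly down remains open. A carboxylic acid on the phenyl ring, or an amine-bearing chain in its place, would test this.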